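Swapping a cyclohexyl for an aryl group on the amine

The compounds below may be only part of what the source reports. "The series", "measured", "known", "first", "only" and "open" are said of these compounds alone.

Of the compounds shown here, two with a shared core have been tested in a functional assay on CHO-K1 cells for antagonist activity at transient receptor potential cation channel subfamily V member 1 (Homo sapiens), read by FLIPR; on this read-out higher numbers stand for weaker inhibition and lower numbers for stronger inhibition. Compound 1 `CC(C(=O)NCc1ccc(C(F)(F)F)nc1NC1CCCCC1)c1ccc(NS(C)(=O)=O)c(F)c1` gives 260 nM, the lower of the two numbers; compound 2 `CC(C(=O)NCc1ccc(C(F)(F)F)nc1NCC1CCN(C(=O)OC(C)(C)C)CC1)c1ccc(NS(C)(=O)=O)c(F)c1` gives 1140 nM, a higher number beyond the usual scatter. Compound 3 `Cc1ccc(Cl)cc1Nc1nc(C(F)(F)F)ccc1CNC(=O)C(C)c1ccc(NS(C)(=O)=O)c(F)c1` has not yet been measured. It differs from compound 1 in one place: 5-chloro-2-methylphenyl in place of cyclohexyl on a nitrogen on an aromatic ring. Going by the values given here, no measured pair shows this kind of change, so the expectation rests on compound 1 alone. The expected change is a 1.7-fold lower number from compound 1 to compound 3 (0.24 log units; within the scatter), a small step toward stronger inhibition or none beyond the scatter. Compound 3 is estimated at 150 nM, ranging from 40 nM to 600 nM.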

Compound 3, half-maximal inhibitory concentration: 140 nM
Compound 3: middle estimate off by 1.1-fold (0.03 log units), on the high side; the range from low to high includes it.
By their numbers in this assay, from the lowest: compounds 3 and 1 (each within the scatter of the next); then compound 2.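

In this assay, the step to 5-chloro-2-methylphenyl in place of cyclohexyl on the nitrogen gives a 1.9-fold lower number from compound 1 to compound 3 (0.27 log units; within the scatter). This position on the shared core therefore holds a substituted aromatic ring as well as a non-aromatic ring of carbon, with no difference beyond the scatter. Nothing available explains why the two groups read alike. On these data alone, whether the chlorine and the methyl matter on their own stays open, and a plain phenyl would test that. How a pyridyl ring would read on this nitrogen is also unknown.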